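The compounds below may be only part of what the source reports. "The series", "measured", "known", "first", "only" and "open" are said of these compounds alone.

Measured so far in a functional assay on NCI-H460 cells (Homo sapiens) for antiproliferative activity, read by CCK-8 assay, with a stated time of 72 h, tested at 8 uM; on this read-out higher numbers stand for a stronger effect at the one concentration tested and lower numbers for a weaker effect:

compound 1 `Nc1ccccc1NC(=O)/C=C/c1ccc(COCNc2nc(Nc3cccc(Cl)c3)c3ncn(C4CCCC4)c3n2)cc1` gives 46.1%
compound 2 `CC(C)n1cnc2c(Nc3cccc(Cl)c3)nc(NCOCc3ccc(/C=C/C(=O)Nc4ccccc4N)cc3)nc21` gives 61.1%
compound 3 `CC(C)n1cnc2c(NCc3ccc(C(=O)Nc4ccccc4N)cc3)nc(Cl)nc21` gives 80.5%

Compound 3 stands highest of the three, and its steps to both others lie beyond the scatter. Compound 2 and compound 1 share one core and differ in a single place: cyclopentyl in place of isopropyl on an aromatic nitrogen In this assay that change made a step of a number 15 percentage points lower from compound 2 to compound 1 (beyond the scatter). The core of compound 3 differs from that of compound 2 in more than one place; the difference between the two cores is not broken down here.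

Compound 4 `Nc1ccccc1NC(=O)c1ccc(CNc2nc(Cl)nc3c2ncn3C2CCCC2)cc1` is not yet measured. It is built from compound 3 by the same change, at the same place: cyclopentyl in place of isopropyl on an aromatic nitrogen Since this change has been seen only once before, and on a different core, the expectation rests on a single earlier step. The expected step is a number 14.5 percentage points lower from compound 3 to compound 4 (beyond the scatter), a fall of similar size, because the earlier step of a number 15 percentage points lower from compound 2 to compound 1 (beyond the scatter) was modest and beyond the scatter. Compound 4 is therefore expected to give about 66% in this assay, most likely between 52% and 79%.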

Compound 4, a percentage reported as inhibition, at one concentration (the size of the read-out at that concentration, not a potency): 57.4%
Compound 4: the middle estimate sits 8.6 percentage points above what was measured, within the range that was stated.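

In this assay, cyclopentyl in place of isopropyl on an aromatic nitrogen again brought the number down, giving a number 23.1 percentage points lower from compound 3 to compound 4 (beyond the scatter). Set beside the earlier case, the change carried over from one core to the other, with a fall of matching size: the same change on two cores in this assay, a number 15 percentage points lower (beyond the scatter) from compound 2 to compound 1 and a number 23.1 percentage points lower (beyond the scatter) from compound 3 to compound 4, 8.1 percentage points apart, within the scatter of two such steps

Within the data shown here, this rests on only two pairs of compounds, each read at a single concentration, so it does not show that the same fall would appear on any further core, nor does it explain why the number falls.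

Only isopropyl and cyclopentyl appear on that nitrogen in the compounds shown, so it remains open how a methyl, an ethyl, a cyclohexyl or a longer chain ending in an amine would read on either core. It also remains open which of the several differences between the two cores accounts for the gap between their values.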